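This account rests on a few compounds, and the source may have more. Where it says the series, first, only, none or still open, it means among the compounds named here.

Of the compounds shown here, two have so far been measured in a functional assay on NCI/ADR-RES cells (Homo sapiens) for positive allosteric modulation, read by MTT assay, with a stated time of 48 h, tested at 10 uM; on this read-out lower numbers stand for stronger inhibition and higher numbers for weaker inhibition. Compound 1 `C=C1[C@H](OC(C)=O)[C@@H](OC(=O)C(C)(C)C)[C@@H](OC(C)=O)C(C)(C)/C=C/[C@H](C)[C@H](OC(=O)c2ccccc2)[C@@]2(O)C[C@@](C)(OC(C)=O)[C@H](OC(C)=O)[C@@H]2[C@H]1OCC(C)C` gives 1730 nM. Compound 2 `C=C1[C@H](OC(C)=O)[C@@H](OC(=O)c2cccc(C)c2)[C@@H](OC(C)=O)C(C)(C)/C=C/[C@H](C)[C@H](OC(=O)c2ccccc2)[C@@]2(O)C[C@@](C)(O)[C@H](OC(C)=O)[C@@H]2[C@H]1OCC(C)C` carries a free hydroxy where compound 1 carries an acetoxy and differs from it in a second ester group as well. In this assay compound 2 gives 980 nM. Compound 2 thus stands at the lowest of the two numbers, but its gap to compound 1 lies within the usual scatter of repeated measurements, so the two cannot be told apart on this read-out.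

Compound 3 `C=C1[C@H](OC(C)=O)[C@@H](OC(=O)c2cccc(C)c2)[C@@H](OC(C)=O)C(C)(C)/C=C/[C@H](C)[C@H](OC(=O)c2ccccc2)[C@@]2(O)C[C@@](C)(OC(C)=O)[C@H](OC(C)=O)[C@@H]2[C@H]1OCC(C)C` has not yet been measured. It differs from compound 2 in a single place: acetyl in place of hydrogen on an oxygen on a saturated carbon. Within the data shown here, no pair of measured compounds shows this change on its own, so any expectation rests only on compound 2 and compound 1, whose numbers are indistinguishable. The expected step, a 1.2-fold higher number from compound 2 to compound 3 (0.09 log units; within the scatter), is therefore small and should not exceed the scatter, because compound 1 with the acetoxy gives 1730 nM in this assay. Compound 3 is expected to give about 1200 nM, with a range from 500 nM to 3000 nM.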

Compound 3, half-maximal inhibitory concentration: 1920 nM
Compound 3: middle estimate off by 1.6-fold (0.20 log units), on the low side; the measured number falls inside the stated range.
By their numbers in this assay, from the lowest: compounds 2, 1 and 3 (each within the scatter of the next).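

Placing an acetyl on the hydrogen of this hydroxy, the hydroxy to acetoxy change on an oxygen on a saturated carbon, gives a 2.0-fold higher number from compound 2 to compound 3 (0.29 log units; within the scatter) in this assay and can now be read on its own, so this small ester adds no measurable difference at this position. At the other ester, 3-methylphenyl in place of tert-butyl on a carbonyl carbon gives a 1.1-fold higher number from compound 1 to compound 3 (0.05 log units; within the scatter) with the acetoxy held constant, so swapping these two groups also leaves the read-out unresolved, and the two differences that compound 1 and compound 2 carried together have each now been seen alone. No independent data bear on either step, so neither can be given an explanation.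

As far as these compounds go, with only a hydrogen and an acetyl compared on this oxygen, it remains open whether a longer chain such as a hexanoyl ester, or an acyl group carrying an amine, would produce a step beyond the scatter. At the other ester, only tert-butyl and 3-methylphenyl appear, so a group such as a pyridine ring or a longer alkyl chain remains an open question there too.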